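Swapping the ester ring in a phosphonate prodrug

The compounds below may be only part of what the source reports. "The series", "measured", "known", "first", "only" and "open" are said of these compounds alone.

Measured compounds:
compound 1, `CC(C)(C)C(=O)OCO[P@@]1(=O)OCC(C)(C)[C@H](C(=O)NCCC(=O)O)O1`, > 1 h
compound 2, `COC(=O)CCNC(=O)[C@@H]1O[P@](=O)(OCOC(=O)c2ocnc2C)OCC1(C)C`, 0.27 h
compound 3, `COC(=O)CCNC(=O)[C@@H]1O[P@@](=O)(OCOC(=O)c2cc(C)nn2C)OCC1(C)C`, > 1 h

These three compounds share a cyclic phosphate core carrying an ester-linked aromatic group, and all were tested in an ADME assay on blood (Homo sapiens) for pharmacokinetics; a lower number here means that the compound disappears faster, a higher number that the compound lasts longer. Compound 1 gives only a limit of the assay, > 1 h. Compound 3 likewise gives only a limit, > 1 h. For the measured compounds named here, compound 2 is the one compound with a real number, 0.27 h, and so it stands alone as the shortest-lived value actually read; (the limit of > 1 h in this assay, at which 2 of the 3 values shown sit).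

Compound 4, `CCc1cc(C(=O)OCO[P@]2(=O)OCC(C)(C)[C@H](C(=O)NCCC(=O)OC)O2)n(C)n1`, is not yet measured. It differs from compound 2 in one place: 3-ethyl-1-methyl-1H-pyrazol-5-yl in place of 4-methyl-1,3-oxazol-5-yl on a carbonyl carbon. Going by the values given here, no measured pair tells how this change alone shifts this assay. Still, compound 3, which also carries a pyrazole-type ester group on the same core, sits at the limit, so a clearly longer half-life is expected for compound 4, well beyond the scatter. The step from compound 2 to compound 4 is estimated as a 5.6-fold higher number from compound 2 to compound 4 (0.74 log units; beyond the scatter). Compound 4 is expected to give 1.5 h, within 0.5 h to 4 h, with a fair chance that only a limit is reported.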

Compound 4, half-life: < 0.16 h
Compound 4 was reported as a limit; the forecaster's own chance of this, stated with the estimate: 60%; at least 9.3-fold (0.97 log units) between middle value and limit.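

For the compounds shown here, the only pair here that differs in one place reads as follows in this assay: putting 3-ethyl-1-methyl-1H-pyrazol-5-yl in place of 4-methyl-1,3-oxazol-5-yl on a carbonyl carbon gives an at least 1.6-fold lower number from compound 2 to compound 4 (0.22 log units; that floor lies within the scatter). Compound 4 is reported only as a limit, not as a number: the limit of < 0.16 h in this assay, at which 1 of the 4 values shown sits.
This pair therefore gives no sign that the larger ring group lengthens the half-life at this place, although the floor of the step alone cannot show a real drop.

The compounds shown leave open how far the true value of compound 4 lies past its limit, and so how large this change really is. They also leave open what a propyl chain in place of the ethyl, or an amine or a carboxylic acid on the ring, would do at this place.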